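Side-chain aryl swap: compound 2 to compound 3

The compounds below may be only part of what the source reports. "The series", "measured", "known", "first", "only" and "open" are said of these compounds alone.

- compound 1 `COc1ccc(COc2cc(/C=C\c3cc(OC)c(OC)c(OC)c3)ccc2OC)cc1` gives 64000 nM
- compound 2 `COc1cccc(/C=C/CCCOc2cc(/C=C\c3cc(OC)c(OC)c(OC)c3)ccc2OC)c1` gives 39000 nM

For the measured compounds named here, in an ADME assay on HEK293 cells (Homo sapiens) for inhibition, read by MTT assay, with a stated time of 3 days (on this read-out higher numbers stand for weaker inhibition and lower numbers for stronger inhibition), compound 1 (64000 nM) and compound 2 (39000 nM) lie within the scatter of each other, so compound 2 stands level with the only other measured compound. Compound 3 `COCOc1ccccc1/C=C/CCCOc1cc(/C=C\c2cc(OC)c(OC)c(OC)c2)ccc1OC` has not yet been measured. It differs from compound 2 by 2-(methoxymethoxy)phenyl in place of 3-methoxyphenyl on a double-bonded chain carbon bound to a double-bonded chain carbon. Going by the values given here, one measured step bears on this, namely a 1.6-fold lower number from compound 1 to compound 2 (0.22 log units; within the scatter) with 4-(3-methoxyphenyl)but-3-en-1-yl in place of 4-methoxyphenyl. That step is small, and it lies within the scatter. Among the compounds with values here, no measured compound carries a 2-(methoxymethoxy)phenyl group, so the evidence is thin and the range must stay wide. The estimated step is a 1.0-fold higher number from compound 2 to compound 3 (0.01 log units; within the scatter) and in this assay none beyond the scatter is expected. For compound 3 the expected value is 40000 nM (estimated range 15000 nM to 100000 nM).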

Compound 3, half-maximal inhibitory concentration: 106000 nM
Beside the measured number, compound 3's estimate is 2.7-fold (0.42 log units) below it; measured number outside the range, above it.
By their numbers in this assay, from the lowest: compounds 2, 1 and 3 (each within the scatter of the next, the first and the last beyond it).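

In this assay, the aryl group on a double-bonded chain carbon bound to a double-bonded chain carbon is not indifferent to substitution: the swap of 3-methoxyphenyl for 2-(methoxymethoxy)phenyl gives a 2.7-fold higher number from compound 2 to compound 3 (0.43 log units; beyond the scatter), a modest change towards weaker inhibition and the only single-place step shown that lies beyond the scatter. The step from the benzylic 4-methoxyphenyl side chain to the longer alkenyl chain did not show this, since it stayed within the scatter, so the aryl group at the chain end matters more here than that earlier change suggested. No measurement shown gives a reason for the step, which remains an observation about this one pair.

The swap changes the ring position and the ether group together, so 2-methoxyphenyl and 3-(methoxymethoxy)phenyl would be needed to tell the two apart. Also open is whether a group of a different kind at this chain end, such as an amine or a carboxylic acid, would shift the number in either direction, as the compounds shown carry only ether-bearing phenyl groups here.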